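Pentyl extension across two cores of the series

This account rests on a few compounds, and the source may have more. Where it says the series, first, only, none or still open, it means among the compounds named here.

The measured compounds are compound 1 `CCC/C(=C\B1OC(C)(C)C(C)(C)O1)C(O)(c1ccccc1)C1CC1`, compound 2 `CCCCCCC(C)(O)/C(=C/B1OC(C)(C)C(C)(C)O1)CCC` and compound 3 `CCCCCCCC/C(=C\B1OC(C)(C)C(C)(C)O1)C(O)(c1ccccc1)C1CC1`; compound 4 `CCCCCCCC/C(=C\B1OC(C)(C)C(C)(C)O1)C(C)(O)CCCCCC` has not been measured. In a functional assay on HT-29 cells (Homo sapiens) for cytotoxicity, read by MTT assay, with a stated time of 72 h (a lower number here means a stronger inhibitor, a higher number a weaker inhibitor), compound 1 gives 83900 nM. In this assay compound 2 gives 57200 nM, a value that lies within the scatter of compound 1. In this assay compound 3 gives 18300 nM, a lower number than compound 2 and beyond the scatter of it.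

Compound 1 and compound 3 share a core and differ only by pentyl in place of hydrogen on a saturated chain carbon, three bonds along the chain from a double-bonded chain carbon; this change brought a 4.6-fold lower number from compound 1 to compound 3 (0.66 log units; beyond the scatter). Compound 2 and compound 4 differ by pentyl in place of hydrogen on a saturated chain carbon, three bonds along the chain from a double-bonded chain carbon, the same change at the same kind of place. The difference between the core of compound 1 and the core of compound 2 is not broken down here.

With one occurrence of the change on one core, and the two cores giving numbers within the scatter of each other before the change, the expectation for compound 4 is a step of similar size, a 4.1-fold lower number from compound 2 to compound 4 (0.61 log units; beyond the scatter), resting on the step of a 4.6-fold lower number from compound 1 to compound 3 (0.66 log units; beyond the scatter) seen between compound 1 and compound 3. A single example carries the expectation. The range is therefore kept wide. Compound 4 is estimated at 14000 nM in this assay, with a likely span from 5000 nM to 40000 nM.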

Compound 4, half-maximal inhibitory concentration: > 100000 nM
Compound 4 ended at the assay's limit; the forecaster's own chance of this, stated with the estimate: 5%; middle value at least 7.1-fold (0.85 log units) away from the limit.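

Compound 4 gives > 100000 nM in this assay, and this is a limit of the assay, not a number: the limit of > 100000 nM in this assay, at which 1 of the 4 values shown sits.

Pentyl in place of hydrogen on a saturated chain carbon, three bonds along the chain from a double-bonded chain carbon, gave a 4.6-fold lower number from compound 1 to compound 3 (0.66 log units; beyond the scatter) on one core but an at least 1.7-fold higher number from compound 2 to compound 4 (0.24 log units; that floor lies within the scatter) on the other, so in this pair of cores the gain seen on the first does not carry over to the second, and the two steps differ: the same change on two cores in this assay, a 4.6-fold lower number (0.66 log units; beyond the scatter) from compound 1 to compound 3 and an at least 1.7-fold higher number (0.24 log units; that floor lies within the scatter) from compound 2 to compound 4, at least 8.0-fold (0.90 log units) apart, beyond the scatter of two such steps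

As far as these compounds go, this rests on a single pair per core, the size of the second step stays unknown with compound 4 at a limit, and nothing here shows which part of the difference between the core of compound 1 and the core of compound 2 goes with the split, as that difference is not broken down.

The compounds shown leave open whether a hexyl chain in place of the octyl chain would give a readable number on the core of compound 2, and so show how the step runs with chain length on that core. They also leave open whether an amine on the octyl chain would bring compound 4 back within the range of the assay.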